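Swapping an Imidazole for a Dimethylamine on Two Cores

The source may hold more compounds than are shown below. What is called first, only, known or untested is meant among the compounds shown, and "the series" means these compounds.

Of the compounds shown here, three have been measured in an ADME assay on MDCK-MDR1 cells (Canis lupus familiaris) for permeability, in the apical to basolateral direction, with a stated time of 180 min; a higher number here means that the compound crosses the layer faster, a lower number that the compound crosses the layer more slowly. Compound 1 `CN(C)CCC(=O)Nc1ccc(C2CCCCC2)cc1` gives 10.8 10^-6 cm/s, compound 3 `O=C(Cn1ccnc1)Nc1ccc(C2CCCCC2)cc1` gives 11.1 10^-6 cm/s, and compound 2 `O=C(Cn1ccnc1)Nc1ccc([C@H]2[C@@H](F)[C@@H](F)C[C@@H](F)[C@H]2F)cc1` gives 0.9 10^-6 cm/s, the lowest of the three.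

Compound 3 and compound 1 differ in a single place: (dimethylamino)methyl in place of 1H-imidazol-1-yl on a saturated chain carbon bound to a carbonyl carbon. This change produced a 1.0-fold lower number from compound 3 to compound 1 (0.01 log units; within the scatter), so on the core of compound 3 the swap left the crossing speed essentially unchanged.

Compound 2 carries a different core from compound 3, and the difference between the two cores is not broken down here; their values alone show that compound 2 crosses the layer far more slowly than compound 3.

Compound 4 `CN(C)CCC(=O)Nc1ccc([C@H]2[C@@H](F)[C@@H](F)C[C@@H](F)[C@H]2F)cc1` has not yet been measured. It arises from compound 2 by the same change: (dimethylamino)methyl in place of 1H-imidazol-1-yl on a saturated chain carbon bound to a carbonyl carbon. The place is identical in both cases, so this is the same change on a second core.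

For compound 4 in this assay the expected step is no change at the digits printed from compound 2 to compound 4 (within the scatter), a size resting on the near-zero step a 1.0-fold lower number from compound 3 to compound 1 (0.01 log units; within the scatter). The estimate for compound 4 is therefore 0.9 10^-6 cm/s, within a range from 0.4 10^-6 cm/s to 2 10^-6 cm/s.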

Compound 4, apparent permeability: 3.7 10^-6 cm/s
Compound 4: the middle estimate sits 4.1-fold (0.61 log units) below what was measured; measured number outside the range, above it.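

In this assay, putting (dimethylamino)methyl in place of 1H-imidazol-1-yl gave a 4.1-fold higher number from compound 2 to compound 4 (0.61 log units; beyond the scatter), so on this core the swap does move the number, whereas on the core of compound 3 it did not. The change therefore does not carry over at the same size from one core to the other: the same change on two cores in this assay, a 1.0-fold lower number (0.01 log units; within the scatter) from compound 3 to compound 1 and a 4.1-fold higher number (0.61 log units; beyond the scatter) from compound 2 to compound 4, 4.2-fold (0.63 log units) apart, beyond the scatter of two such steps. This shows that, for these two pairs, the core on which the swap is made matters to the size of the step, but it does not show which part of the core is responsible, and two cores are too few to predict the step on a third.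

As far as these compounds go, it remains open whether the gap between the two cores is special to this swap or also appears with other groups at the same place, such as a diethylamino group or a carboxylic acid. From the compounds shown here alone, a longer chain between the carbonyl carbon and the amine is equally open on both cores.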